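Pyridin-2-yl in place of hydroxy: series notes

The compounds below may be only part of what the source reports. "The series", "measured", "known", "first", "only" and "open" are said of these compounds alone.

In a functional assay on KB cells (Homo sapiens) for inhibition, read by MTT assay, with a stated time of 24 h, tested at 0.1 ug/mL (a higher number here means more inhibition of growth at the concentration tested, a lower number less inhibition of growth), compound 1 (`O=C(CCCCC(S)CCS)NO`) gives 7.62%, within the scatter of compound 2 (`O=C(CCCCC(S)CCS)Nc1ccc(OC(F)(F)F)cc1`) at 7.27%. Compound 3 (`O=C(CCCCC(S)CCS)Nc1ccc([N+](=O)[O-])c(C(F)(F)F)c1`) gives "not active" (no number reported), with no number reported. Compound 4 (`O=C(CCCCC(S)CCS)Nc1ccccn1`) carries pyridin-2-yl in place of hydroxy on an amide-type nitrogen. Compound 2 also lacks the hydroxy and gives 7.27%, while compound 3 also lacks it and gives "not active" (no number reported), so replacing that group shows no single outcome. No change beyond the scatter is expected in this assay, although a result without a number remains possible. The expected a number 1.6 percentage points lower from compound 1 to compound 4 (within the scatter) stays within the scatter. For compound 4 the estimated value is 6%, with an expected range of 1% to 14%.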

Compound 4, percent growth inhibition at one concentration: "not active" (no number reported)
No number was reported for compound 4, so the estimate cannot be set against anything.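

Among the compounds shown here, compound 4 gives no number, so no step from compound 1 to compound 4 can be read, and no measured evidence bears on this result. On these data alone, whether pyridin-2-yl in place of hydroxy alters the outcome in this assay stays open.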